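Compound 3 to compound 4: azidomethyl on the carbonyl carbon

This account rests on a few compounds, and the source may have more. Where it says the series, first, only, none or still open, it means among the compounds named here.

compound 1 `CCCCC(=O)N(Cc1ccc(OC)c(O)c1)c1cc(OC)c(OC)c(OC)c1` gives 66 nM
compound 2 `COc1ccc(CN(C(C)=O)c2cc(OC)c(OC)c(OC)c2)cc1O` gives 79 nM
compound 3 `C/C=C/C=C/C(=O)N(Cc1ccc(OC)c(O)c1)c1cc(OC)c(OC)c(OC)c1` gives 140 nM

In a functional assay on MGC-803 cells (Homo sapiens) for inhibition, read by MTT assay, with a stated time of 48 h (a higher number here means a weaker inhibitor, a lower number a stronger inhibitor), compound 3 stands at 140 nM. Its two measured neighbours are reached by a 2.1-fold higher number from compound 1 to compound 3 (0.33 log units; beyond the scatter) and a 1.8-fold higher number from compound 2 to compound 3 (0.25 log units; within the scatter), so it is set apart from compound 1 only.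

Compound 4 `COc1ccc(CN(C(=O)CN=[N+]=[N-])c2cc(OC)c(OC)c(OC)c2)cc1O` carries azidomethyl in place of penta-1,3-dien-1-yl on a carbonyl carbon. All three measured steps change the group at this same place, and all are small: besides the two above there is a 1.2-fold higher number from compound 1 to compound 2 (0.08 log units; within the scatter). For the measured compounds named here, no measured compound carries azidomethyl, so the size of this step rests only on that narrow spread. A small step in this assay toward a lower number is expected, probably not beyond the scatter, with compound 4 falling near compound 2 at 79 nM. The expected change is a 1.6-fold lower number from compound 3 to compound 4 (0.19 log units; within the scatter). The estimate for compound 4 is 90 nM, with an expected range of 40 nM to 200 nM.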

Compound 4, half-maximal inhibitory concentration: 120 nM
Compound 4: the middle estimate sits 1.3-fold (0.12 log units) below what was measured; measured number inside the range.
By their numbers in this assay, from the lowest: compounds 1, 2, 4 and 3 (each within the scatter of the next, the first and the last beyond it).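

In this assay, for the compounds shown here, azidomethyl on the carbonyl carbon brings in the only nitrogen-bearing group at this place, yet compound 4 stays within the scatter of all three neighbours (a 1.2-fold lower number from compound 3 to compound 4 (0.07 log units; within the scatter)) (a 1.5-fold higher number from compound 2 to compound 4 (0.18 log units; within the scatter)) (a 1.8-fold higher number from compound 1 to compound 4 (0.26 log units; within the scatter)). Going by these compounds alone, the position therefore accepts azidomethyl as well as the all-carbon butyl, methyl and penta-1,3-dien-1-yl groups, and the only step here beyond the scatter remains the one between compound 1 and compound 3. No measured property bears on this result, so the flat response stands without explanation.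

From the compounds shown here alone, how an aminomethyl group, a carboxylic acid, a chain longer than butyl or a phenyl ring on the carbonyl carbon would behave remains open. All four compounds share one core, so these results say nothing about changes made elsewhere on it.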